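The source may hold more compounds than are shown below. What is called first, only, known or untested is meant among the compounds shown, and "the series" means these compounds.

Measured in a physicochemical assay for solubility; on this read-out lower numbers stand for lower solubility and higher numbers for higher solubility:
- compound 1 `CNC(=O)c1cc(C(=O)NC2CC2)cc2c1OC[C@H]2c1cccc2[nH]ccc12`: >= 142 ug/mL, a limit
- compound 2 `CNC(=O)c1cc(C(=O)N[C@H]2[C@@H]3COC[C@@H]32)cc2c1OC[C@H]2c1cccc2[nH]ccc12`: >= 171 ug/mL, a limit

Compound 1 therefore stands at a limit and has no exact number. Compound 3 `CNC(=O)c1cc(C(=O)NC2CC2)cc2c1OC[C@H]2c1cccc(OC)c1` carries 3-methoxyphenyl in place of 1H-indol-4-yl on a saturated ring carbon. Within the data shown here, the only measured step, a step that the two limits leave unreadable from compound 1 to compound 2, lies on an amide-type nitrogen and gives no size for this change. No step beyond the scatter is therefore expected, in either direction, and this assay may again report only a limit. The expected step is an at least 1.0-fold lower number from compound 1 to compound 3 (0.00 log units; that floor lies within the scatter). Compound 3 is estimated at 140 ug/mL, with an expected range of 70 ug/mL to 250 ug/mL.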

Compound 3, solubility: >= 161 ug/mL
Compound 3: no number, only a limit (the forecaster's own chance of this, stated with the estimate: 55%); middle value at least 1.1-fold (0.06 log units) away from the limit.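

In this assay compound 3 gives >= 161 ug/mL, a limit. Among these compounds, compound 1 also stands at a limit, so no step between compound 1 and compound 3 can be read. The compounds shown leave open what size of step 3-methoxyphenyl in place of 1H-indol-4-yl brings.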